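The source may hold more compounds than are shown below. What is called first, only, known or untested is meant among the compounds shown, and "the series" means these compounds.

Compound 1 `COc1ccc2cc([C@H](C)c3nnc(SCc4c(C)cc(C)cc4C)n3-c3cccc(Cl)c3)ccc2c1`: 93300 nM
Compound 2 `COc1ccc(CSc2nnc([C@@H](C)c3ccc4cc(OC)ccc4c3)n2-c2ccc(F)cc2)cc1`: <= 400000 nM

In a functional assay on DU-145 cells (Homo sapiens) for cytotoxicity, read by MTT assay (on this read-out lower numbers stand for stronger inhibition and higher numbers for weaker inhibition), compound 2 stands only as a limit, <= 400000 nM, and not as a number. Compound 3 `COc1ccc2cc([C@H](C)c3nnc(SCc4c(C)cc(C)cc4C)n3-c3ccc(F)cc3)ccc2c1` carries 2,4,6-trimethylphenyl in place of 4-methoxyphenyl on a saturated chain carbon bound to a sulfur. No measured step sizes this change. Among the measured compounds shown here, the only true number available is that of compound 1, 93300 nM, so the expectation leans on that value. The expected change is a step that the limit leaves unreadable from compound 2 to compound 3, a modest move towards stronger inhibition, and it is uncertain since one end is a limit. For compound 3 the estimate is 100000 nM, with an expected range of 30000 nM to 300000 nM.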

Compound 3, half-maximal inhibitory concentration: 10200 nM
The estimate for compound 3 lay 9.8-fold (0.99 log units) above the measured number, outside the stated range (below it).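

In this assay, 4-fluorophenyl in place of 3-chlorophenyl on an aromatic nitrogen gives a 9.1-fold lower number from compound 1 to compound 3 (0.96 log units; beyond the scatter), with 2,4,6-trimethylphenyl kept on the saturated chain carbon bound to a sulfur. This first sized step shows that the group on the aromatic nitrogen can move the number beyond the scatter. The change from 4-methoxyphenyl to 2,4,6-trimethylphenyl cannot be read because compound 2 stands only as a limit: the limit of <= 400000 nM in this assay, at which 1 of the 3 values shown sits.

Going by these compounds, whether the fluorophenyl gain holds with 4-methoxyphenyl on the chain carbon remains open. So does the effect of an amine or a carboxylic acid in place of 4-fluorophenyl on the aromatic nitrogen.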